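Compound 3: hydroxy in place of ((thiophen-2-yl)sulfonyl)amino

The source may report more compounds than this note shows. Statements on the series, on what has been measured and on what is new or still open speak of the compounds shown alone.

Of the compounds shown here, two with a shared core have been read in an ADME assay on microsomes from liver (Mus musculus) for metabolic stability, read by LC-MS, with NADPH named in the record, with a stated time of 60 min, tested at 1 uM, in the absence of a further agent; a lower number here means that less of the compound is left, a higher number that more of the compound is left. Compound 1 (`COc1ccc(-c2c(C)nc3c(N4CC[C@@H](NC(=O)OCc5ccccc5)C4)cc(C)nn23)cc1OC`) gives > 95% as a limit of the assay and not a number. Compound 2 (`COc1ccc(-c2c(C)nc3c(N4CC[C@@H](NS(=O)(=O)c5cccs5)C4)cc(C)nn23)cc1OC`) gives > 95% as a limit too. Compound 2 therefore stands at the limit of > 95% in this assay, at which 2 of the 2 values shown sit, and has no number of its own.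

The next step leads to compound 3 (`COc1ccc(-c2c(C)nc3c(N4CC[C@@H](O)C4)cc(C)nn23)cc1OC`), with hydroxy in place of ((thiophen-2-yl)sulfonyl)amino on a saturated ring carbon. The core stays unchanged.

Going by the values given here, the only measured step that bears on this is a step that the two limits leave unreadable from compound 1 to compound 2 and it has (thiophen-2-yl)sulfonyl in place of benzyloxycarbonyl on an amine nitrogen. Among the compounds with values here, it offers no size to carry over, and no measured compound has lost the amine-linked group. The expectation therefore rests on the high reading of the two measured compounds, with some allowance for a fall. The estimated step of a number at least 5 percentage points lower from compound 2 to compound 3 (that floor lies within the scatter) is expected to be small and, if readable at all, downward. For compound 3 the expected value in this assay is 90% (estimated range 70% to 100%).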

Compound 3, percent of the compound remaining: > 95%
Compound 3 ended at the assay's limit; the forecaster's own chance of this, stated with the estimate: 45%; middle value at least 5 percentage points from the limit.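

In this assay compound 3 gives > 95%, a limit of the assay and not a number. The steps from compound 1 and compound 2 to compound 3 therefore cannot be read: the limit of > 95% in this assay, at which 3 of the 3 values shown sit. The compounds shown leave open whether hydroxy, (benzyloxycarbonyl)amino and ((thiophen-2-yl)sulfonyl)amino differ at all in the share of compound remaining.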